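The source may report more compounds than this note shows. Statements on the series, on what has been measured and on what is new or still open speak of the compounds shown alone.

In a functional assay on MCF7 cells (Homo sapiens) for inhibition, read by MTT assay, with a stated time of 72 h (a higher number here means a weaker inhibitor, a lower number a stronger inhibitor), compound 2 `CCN1C(=O)N(CC)C2C1NC(=S)N2/N=C/C=C/c1ccccc1` gives 36100 nM, and this is the only actual figure among the three measured compounds. Compound 1 `CN1C(=O)N(c2ccccc2)C2NC(=S)N(/N=C/C=C/c3ccccc3)C21` reaches only a limit of the assay, > 100000 nM. Compound 3 `CCN1C(=O)N(CC)C2C1NC(=S)N2/N=C/C=C/c1ccccc1OC` likewise gives only a limit, > 100000 nM. Within the data shown here, the one step that can be sized is an at least 2.7-fold higher number from compound 2 to compound 3 (0.44 log units; beyond the scatter), and it rests on (the limit of > 100000 nM in this assay, at which 2 of the 3 values shown sit).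

Compound 4 `CCN1C(=O)N(c2ccccc2)C2NC(=S)N(/N=C/C=C/c3ccccc3)C21` differs from compound 2 by phenyl in place of ethyl on an amide-type nitrogen in a ring. Among the measured compounds shown here, no measured step covers this change directly. The methoxy step from compound 2 to compound 3 concerns the aromatic ring of the side chain, not the ring nitrogen, so it bears only loosely on the question. What the values of compound 1 and compound 2 show is that the compound carrying phenyl groups on both amide-type nitrogens sits at the limit while the diethyl compound yields a number; compound 4 carries one phenyl and one ethyl, so a weaker result than compound 2 is expected, with a real chance of another limit. The expected step is a 2.1-fold higher number from compound 2 to compound 4 (0.32 log units; beyond the scatter), toward a higher number. Compound 4 is therefore estimated at 75000 nM, in a range from 25000 nM to 200000 nM.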

Compound 4, half-maximal inhibitory concentration: 2250 nM
Beside the measured number, compound 4's estimate is 33-fold (1.52 log units) above it; measured number outside the range, below it.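

In this assay, phenyl in place of ethyl on an amide-type nitrogen in a ring gives a 16-fold lower number from compound 2 to compound 4 (1.21 log units; beyond the scatter), the first sign that this nitrogen strongly affects the result, and compound 4 now gives the lowest number of the measured compounds. Phenyl alone does not account for this: compound 1 also carries phenyl on such a nitrogen, and methyl in place of hydrogen on the saturated chain carbon bound to the other amide-type nitrogen in the ring gives an at least 44-fold lower number from compound 1 to compound 4 (1.64 log units; beyond the scatter), so the ethyl group that remains in compound 4 matters as well. That second step is only a bound, not a measured size, because compound 1 stands at a limit of the assay: the limit of > 100000 nM in this assay, at which 2 of the 4 values shown sit.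

The compounds shown do not tell whether the gain belongs to phenyl itself or would also appear with a benzyl or cyclohexyl group, or with a phenyl ring bearing a chlorine or a methoxy group, on that nitrogen. They also leave open whether a propyl chain in place of the remaining ethyl would lower the number further, and how the methoxy group of compound 3 would behave alongside the phenyl of compound 4.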